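Swapping the amide headgroup: from compound 3 to compound 4

A few compounds are considered here, and "the series" means these few. Any claim that something is new, unique, unknown or untested is made for them only; others in the source may bear on it.

Measured so far:
- compound 1, `O=C(NCc1ccc(S(=O)(=O)N2CCCCC2)cc1)c1ccn2cncc2c1`: > 10000 nM
- compound 2, `O=C(NCc1ccc(S(=O)(=O)c2ccccc2C(F)(F)F)cc1)c1cc2cnccc2[nH]1`: 25 nM
- compound 3, `O=C(NCc1ccc(S(=O)(=O)c2ccccc2)cc1)c1nc2cnccc2[nH]1`: 5400 nM

Of the compounds shown here, three have been tested in a functional assay on A2780 cells (Homo sapiens) for inhibition, read by sulforhodamine B assay, with a stated time of 72 h; a higher number here means a weaker inhibitor, a lower number a stronger inhibitor. Compound 1 gives only a limit of the assay, > 10000 nM, not a number; this is the limit described as the limit of > 10000 nM in this assay, at which 1 of the 3 values shown sits. Among the two compounds with an actual number, compound 3 stands highest, with 5400 nM, while compound 2 gives 25 nM, a gap that is far beyond the usual scatter. Compound 2 also differs from compound 3 in more than one place, so this gap cannot be pinned on a single change.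

Compound 4, `O=C(NCc1ccc(S(=O)(=O)c2ccccc2)cc1)c1nc2ccncc2s1`, has not yet been measured. It differs from compound 3 in one place: a group of 9 heavy atoms (6 carbon, 2 nitrogen, 1 sulfur; one five-membered aromatic ring with 2 hetero atoms, one six-membered aromatic ring with 1 hetero atom) in place of a group of 9 heavy atoms (6 carbon, 3 nitrogen; one five-membered aromatic ring with 2 hetero atoms, one six-membered aromatic ring with 1 hetero atom), on a carbonyl carbon. For the measured compounds named here, no step between measured compounds matches this change, so there is no direct guide to its size. The expectation here is a step from compound 3 of about a 1.1-fold higher number from compound 3 to compound 4 (0.05 log units; within the scatter), which is not clearly beyond the scatter in either direction. Compound 4 is therefore expected to give about 6000 nM, within a range from 1500 nM to 20000 nM.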

Compound 4, half-maximal inhibitory concentration: > 10000 nM
Compound 4: a limit, no number; the forecaster's own chance of this, stated with the estimate: 25%; middle value at least 1.6-fold (0.22 log units) away from the limit.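

This swap on the carbonyl carbon gives the only direct comparison shown between two compounds that differ in one place, and it reads as an at least 1.8-fold higher number from compound 3 to compound 4 (0.26 log units; that floor lies within the scatter). In this assay compound 4 gives > 10000 nM, which is a limit of the assay and not a number. The change therefore brings no gain that this assay can detect, but the true size of the step stays unknown, and only a floor can be given because the reading stops at the assay's limit: the limit of > 10000 nM in this assay, at which 2 of the 4 values shown sit.

The swap also changes two things at once, since a ring nitrogen gives way to sulfur and the count of hydrogen-bond donors falls from 1 to 0, so these compounds cannot show which of the two matters, or whether either does. A group with a methyl on that nitrogen in place of its hydrogen, or one with oxygen in place of the sulfur, would be needed to separate the two, and the same swap on the trifluoromethyl-bearing sulfone of compound 2 remains an open comparison.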